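Bromo for isopropyl at the cytotoxicity limit

The compounds below may be only part of what the source reports. "The series", "measured", "known", "first", "only" and "open" are said of these compounds alone.

Compound 1 `CC(C)c1ccc(C(Nc2ccc(C3(C)NC(=O)c4ccccc4N3)cc2)c2nnnn2C2CCCCC2)cc1`: > 400000 nM (a limit)
Compound 2 `CC(C)c1ccc(C(Nc2ccc(C3(C)NC(=O)c4ccccc4N3)cc2)c2nnnn2C(C)(C)C)cc1`: > 400000 nM (a limit)
Compound 3 `CC1(c2ccc(NC(c3ccc(Cl)cc3)c3nnnn3C(C)(C)C)cc2)NC(=O)c2ccccc2N1`: > 400000 nM (a limit)

In an ADME assay on J774.A1 cells (Mus musculus) for cytotoxicity, read by MTT assay, with a stated time of 72 h (on this read-out higher numbers stand for lower toxicity in this test and lower numbers for higher toxicity in this test), compound 1 gives only a limit, > 400000 nM. All three measured compounds share that position: the limit of > 400000 nM in this assay, at which 3 of the 3 values shown sit.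

Compound 4 `CC1(c2ccc(NC(c3ccc(Br)cc3)c3nnnn3C3CCCCC3)cc2)NC(=O)c2ccccc2N1` departs from compound 1 by one change, (bromo in place of isopropyl on an aromatic carbon). It is bromo in place of isopropyl on an aromatic carbon, para to a large group, so that 4-isopropylphenyl becomes 4-bromophenyl.

Among the measured compounds shown here, two measured steps bear on this change. The closer one is a step that the two limits leave unreadable from compound 2 to compound 3, with chloro in place of isopropyl on an aromatic carbon. The other is a step that the two limits leave unreadable from compound 1 to compound 2, with tert-butyl in place of cyclohexyl on an aromatic nitrogen, a change that compound 4 does not make. Neither step has a readable size, so neither supplies a number to carry over.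

The expectation rests mainly on compound 3, whose value is still the limit > 400000 nM. In this assay the expected result is a number no higher from compound 1 to compound 4 (the limit leaves the size open), with no step beyond the scatter in either direction. For compound 4 the estimate is 400000 nM, with an expected range from 200000 nM to 800000 nM.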

Compound 4, half-maximal cytotoxic concentration: > 400000 nM
Compound 4: no number, only a limit; the forecaster's own chance of this, stated with the estimate: 85%; the middle value sits exactly at the limit.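

In this assay compound 4 gives only a limit, > 400000 nM. Among the compounds shown here, compound 1 gives only a limit as well, so no step between compound 1 and compound 4 can be read. The compounds shown leave open whether bromo and isopropyl differ at all on this read-out, and how toxic any of these compounds is: the limit of > 400000 nM in this assay, at which 4 of the 4 values shown sit.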